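Para-methyl anilide on the dinitro core

The source may hold more compounds than are shown below. What is called first, only, known or untested is meant among the compounds shown, and "the series" means these compounds.

Measured compounds:
compound 1, `Cc1ccc(NC(=O)/C=C/C(=O)N2C/C(=C\c3ccccc3)C(=O)/C(=C/c3ccccc3)C2)cc1`, 660 nM
compound 2, `Cc1ccc(NC(=O)/C=C/C(=O)N2C/C(=C\c3ccccc3)C(=O)/C(=C/c3ccccc3)C2)cc1C`, 7900 nM
compound 3, `O=C(/C=C/C(=O)N1C/C(=C\c2ccc([N+](=O)[O-])cc2)C(=O)/C(=C/c2ccc([N+](=O)[O-])cc2)C1)Nc1ccccc1`, 360 nM

In a functional assay on Molt4/C8 cells (Homo sapiens) for cytotoxicity (a lower number here means a stronger inhibitor, a higher number a weaker inhibitor), compound 3 gives the lowest of the three numbers, though against compound 1 the gap is within the scatter. Compound 2 stands well apart: the step of a 12-fold higher number from compound 1 to compound 2 (1.08 log units; beyond the scatter) is large and beyond the scatter, and the change behind it is methyl in place of hydrogen on an aromatic carbon.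

Compound 4, `Cc1ccc(NC(=O)/C=C/C(=O)N2C/C(=C\c3ccc([N+](=O)[O-])cc3)C(=O)/C(=C/c3ccc([N+](=O)[O-])cc3)C2)cc1`, has not yet been measured in this assay. It is made from compound 3 by methyl in place of hydrogen on an aromatic carbon. Within the data shown here, this is the same kind of change as the one from compound 1 to compound 2, but not the same: in compound 2 the entering methyl sits ortho to a methyl group and meta to a large group, whereas in compound 4 it sits para to a large group, with no other methyl on that ring. How the core of compound 3 differs from the core of compound 1 is not broken down here.

Among the measured compounds shown here, the only measured step for this kind of change, a 12-fold higher number from compound 1 to compound 2 (1.08 log units; beyond the scatter), points toward a weaker inhibitor, but its surroundings differ from those in compound 4, so its size cannot simply be carried over. A smaller step, a 2.8-fold higher number from compound 3 to compound 4 (0.44 log units; beyond the scatter), is expected from compound 3 to compound 4 in this assay. Compound 4 is therefore estimated at 1000 nM, with a likely range from 300 nM to 5000 nM.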

Compound 4, half-maximal inhibitory concentration: 700 nM
For compound 4 the middle estimate is 1.4-fold (0.15 log units) above the measured one; low and high end bracket the measured number.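

In this assay the new step is a 1.9-fold higher number from compound 3 to compound 4 (0.29 log units; within the scatter), so this assay does not tell compound 3 and compound 4 apart. Set beside the earlier step, the size of this change does not carry over unchanged between the two cores: the same change on two cores in this assay, a 12-fold higher number (1.08 log units; beyond the scatter) from compound 1 to compound 2 and a 1.9-fold higher number (0.29 log units; within the scatter) from compound 3 to compound 4, 6.2-fold (0.79 log units) apart, beyond the scatter of two such steps. Among these compounds, this does not show that the core alone sets the size of the step: the methyl in compound 4 sits para to a large group on a ring with no other methyl, the one entering compound 2 joins a ring that already carries a methyl, and two steps cannot separate core from placement.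

The compounds shown leave open how the plain phenyl amide behaves on the core of compound 1 and how a second methyl on that ring behaves on the core of compound 3, either of which would put the same placement on both cores. Also open, as far as these compounds go, is whether an ethyl, a methoxy or a chlorine in place of this methyl would follow the same course on either core.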